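Ester alkyl size at the enol oxygen and atrial response

The source may hold more compounds than are shown below. What is called first, only, known or untested is meant among the compounds shown, and "the series" means these compounds.

Compound 1 `CC1=NC(C)=C([N+](=O)[O-])C(c2ccccn2)/C1=C(\O)OC1CCCC1` is the cyclopentyl ester of the series. Among the compounds with values here, in a functional assay (cardiac atrium) for agonist activity, with Cavia porcellus as the target (a higher number here means that more compound is needed for the effect, a lower number that less compound is needed), compound 1 gives 19800 nM, the second highest of the three numbers so far. Compound 2 `CO/C(O)=C1\C(C)=NC(C)=C([N+](=O)[O-])C1c1ccncc1`, the methyl ester on a slightly different core, gives 48500 nM in this assay, and compound 3 `CC1=NC(C)=C([N+](=O)[O-])C(c2ccncc2)/C1=C(\O)OC(C)(C)C`, the tert-butyl ester on that same core, gives 2820 nM. Within the data shown here, the only single-point step measured so far is a 17-fold lower number from compound 2 to compound 3 (1.24 log units; beyond the scatter), where a larger alkyl on the same oxygen as in compound 4 cuts the number sharply.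

Compound 4 `CCO/C(O)=C1\C(C)=NC(C)=C([N+](=O)[O-])C1c1ccccn1` arises from compound 1 by ethyl in place of cyclopentyl on an oxygen on an unsaturated carbon. This runs in the opposite direction to the step from compound 2 to compound 3: the alkyl on the oxygen shrinks rather than grows. Among the measured compounds shown here, that step is the only guide, and it comes from a core that is not identical to that of compound 1, so it is weighed with caution. A move toward a higher number in this assay is expected for compound 4, a 2.5-fold higher number from compound 1 to compound 4 (0.40 log units; beyond the scatter), smaller than the step seen between compound 2 and compound 3. Compound 4 is therefore estimated at 50000 nM, with a range of 15000 nM to 160000 nM.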

Compound 4, half-maximal effective concentration: 22800 nM
For compound 4 the middle estimate is 2.2-fold (0.34 log units) above the measured one; the range from low to high includes it.
By their numbers in this assay, from the lowest: compound 3; then compounds 1 and 4 (each within the scatter of the next); then compound 2.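

In this assay, ethyl in place of cyclopentyl on an oxygen on an unsaturated carbon gives a 1.2-fold higher number from compound 1 to compound 4 (0.06 log units; within the scatter) on the core of compound 1, so these two esters cannot be told apart. On this core, the loss of the five-membered carbon ring therefore has no readable effect, unlike the step on the other core, a 17-fold lower number from compound 2 to compound 3 (1.24 log units; beyond the scatter) in that pair, so alkyl size at this oxygen does not act as a single rule across the two cores. The data on hand offer no explanation for this contrast.

Still open, going by these compounds, is whether a tert-butyl ester on the core of compound 1 would approach compound 3 at 2820 nM or whether that low number belongs to its own core. On these data alone, how a longer chain or an alkyl group carrying an amine would behave at this oxygen also remains unknown.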